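Dropping a Methoxy Group from a Benzylamide Side Chain

The source may hold more compounds than are shown below. What is called first, only, known or untested is meant among the compounds shown, and "the series" means these compounds.

Of the compounds shown here, three built on one shared core have been tested in a functional assay on MDA-MB-435 cells (Homo sapiens) for cytotoxicity, read by MTT assay, with a stated time of 72 h; on this read-out lower numbers stand for stronger inhibition and higher numbers for weaker inhibition. Compound 1 `O=C(NCc1ccc(F)cc1)c1nc(Br)c2cccnc2c1NCCCNc1c(C(=O)NCc2ccc(F)cc2)nc(Br)c2cccnc12` joins two copies of the core through a three-carbon chain; in this assay compound 1 gives only a limit, > 20000 nM, and no number. Compound 2 `N[C@H]1CC[C@H](NC(=O)c2nc(Br)c3cccnc3c2NCc2ccc(F)cc2)CC1` carries the aminocyclohexyl group on the amide and the fluorobenzyl group on the amine; in this assay compound 2 gives 6600 nM. Compound 3 `COc1ccc(CNC(=O)c2nc(Br)c3cccnc3c2N[C@H]2CC[C@H](N)CC2)cc1` swaps these places, the aminocyclohexyl group now on the amine and a methoxybenzyl group on the amide; in this assay compound 3 gives 5000 nM. Of the two numbers, that of compound 3 is the lower, but the gap to compound 2 lies within the usual scatter, so the two cannot be ranked.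

Compound 4 `N[C@H]1CC[C@H](Nc2c(C(=O)NCc3ccccc3)nc(Br)c3cccnc23)CC1` is not yet measured. It differs from compound 3 in one place: hydrogen in place of methoxy on an aromatic carbon. Within the data shown here, no pair of measured compounds shows what this change does, and in this assay the step from compound 3 to compound 4 is expected to be small, a 1.2-fold higher number from compound 3 to compound 4 (0.08 log units; within the scatter), in no sure direction beyond the scatter. In this assay compound 4 is therefore expected to give about 6000 nM, somewhere between 2500 nM and 15000 nM.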

Compound 4, half-maximal inhibitory concentration: 7000 nM
Beside the measured number, compound 4's estimate is 1.2-fold (0.07 log units) below it, and the stated range covers the measured number.
By their numbers in this assay, from the lowest: compounds 3, 2 and 4 (each within the scatter of the next). At a limit, above all of these: compound 1.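

Among these compounds, compound 3 and compound 4 form the first measured pair that differs in one place only, which gives the first direct reading in this assay of what the methoxy group does at this position: the step is a 1.4-fold higher number from compound 3 to compound 4 (0.15 log units; within the scatter). So the 4-methoxybenzyl and benzyl forms of the amide side chain cannot be ranked, and on this read-out the methoxy group can give way to a plain hydrogen on the aromatic carbon without a shift that stands clear of the usual scatter. The measurements shown offer no reason why this step is so small.

Going by these compounds, what stays open is whether any group at this place can move the number beyond the scatter, which a hydroxyl group, a chlorine atom or a nitrile would help to show. Also open, on these data alone, is how much the benzyl group itself matters to the amide, a question that a plain methyl amide or a longer phenylethyl chain could address.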